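Swapping a sulfonyl ester for a sulfonamide

A few compounds are considered here, and "the series" means these few. Any claim that something is new, unique, unknown or untested is made for them only; others in the source may bear on it.

Three thioureas with a shared core have been tested in a functional assay for antagonist activity at Vanilloid receptor (Rattus norvegicus); a lower number here means a stronger inhibitor, a higher number a weaker inhibitor. Compound 1 `CC(C)(C)c1ccc(C/N=C(\S)NCc2ccc(C(F)(F)F)cc2)cc1` gives 12400 nM. Compound 2 `CC(C)(C)c1ccc(C/N=C(\S)NCc2ccc(OS(C)(=O)=O)cc2)cc1` gives 9300 nM. Compound 3 `CC(C)S(=O)(=O)Nc1ccc(C/N=C(\S)NCc2ccc(C(C)(C)C)cc2)cc1` gives 3800 nM. Among these three numbers compound 2 stands second highest: its nearest neighbour is compound 1, and the step of a 1.3-fold lower number from compound 1 to compound 2 (0.12 log units; within the scatter) lies within the scatter, whereas compound 3 gives a number lower than that of compound 2 by more than the scatter.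

Compound 4 `CC(C)(C)c1ccc(C/N=C(\S)NCc2ccc(NS(=O)(=O)C(F)(F)F)cc2)cc1` has not yet been measured in this assay. It differs from compound 2 in one place: ((trifluoromethyl)sulfonyl)amino in place of (methylsulfonyl)oxy on an aromatic carbon. Going by the values given here, only one measured step touches this position, the step of a 1.3-fold lower number from compound 1 to compound 2 (0.12 log units; within the scatter), and it stayed within the scatter, so a change here has so far moved the number little. Among the compounds with values here, a sulfonyl group joined to an amino group also occurs in compound 3, whose number 3800 nM is the lowest of the three, but no single step links compound 3 to compound 2, so that pair only shows what its two values are. A small to moderate step towards a lower number, a 3.7-fold lower number from compound 2 to compound 4 (0.57 log units; beyond the scatter), is therefore expected. Compound 4 is estimated at 2500 nM, with a range from 500 nM to 12000 nM.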

Compound 4, half-maximal inhibitory concentration: 12400 nM
The estimate for compound 4 lay 5.0-fold (0.70 log units) below the measured number; measured number outside the range, above it.
By their numbers in this assay, from the lowest: compound 3; then compounds 2, 1 and 4 (each within the scatter of the next).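

In this assay, the position on an aromatic carbon para to a large group has now carried three different groups, and the numbers remain within the scatter of one another. Replacing (methylsulfonyl)oxy with ((trifluoromethyl)sulfonyl)amino gives a 1.3-fold higher number from compound 2 to compound 4 (0.12 log units; within the scatter) and so brings no real change, and replacing trifluoromethyl with the same group gives no change at the digits printed from compound 1 to compound 4 (within the scatter) as well. A sulfonyl group joined to an amino group is therefore not enough on its own to lower the number, as compound 4 carries such a unit and still does not reach the value of compound 3, 3800 nM in this assay, while no measurement shown here offers an explanation for the flat result.

The compounds shown leave open whether a group of another kind at this position, such as an amine or a carboxylic acid, would move the number beyond the scatter. They also leave open how the number responds when only the group on the sulfur of the sulfonylamino unit is changed, for example to a longer carbon chain.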